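A few compounds are considered here, and "the series" means these few. Any claim that something is new, unique, unknown or untested is made for them only; others in the source may bear on it.

Compound 1 `COc1cc(/C=C/C(=O)c2cccc(-n3cc(-c4ccc(Cl)cc4)[nH]c3=O)c2)ccc1O` is one of three compounds sharing a core that was tested in a functional assay on A549 cells (Homo sapiens) for inhibition (on this read-out higher numbers stand for weaker inhibition of growth and lower numbers for stronger inhibition of growth), where compound 1 gives 6780 nM. Compound 2 `COc1cc(/C=C/C(=O)c2cccc(-n3cc(-c4ccccc4)[nH]c3=O)c2)ccc1O` gives 3850 nM, and compound 3 `COc1ccc(-c2cn(-c3cccc(C(=O)/C=C/c4cc(OC)c(OC)c(OC)c4)c3)c(=O)[nH]2)cc1` gives 11800 nM. Compound 1 therefore stands second highest of the three numbers, with its step to each neighbour within the scatter.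

Compound 4 `COc1ccc(-c2cn(-c3cccc(C(=O)/C=C/c4ccc(O)c(OC)c4)c3)c(=O)[nH]2)cc1` has not yet been measured. It differs from compound 1 in a single place: methoxy in place of chloro on an aromatic carbon. Put another way, a 4-chlorophenyl becomes a 4-methoxyphenyl.

Going by the values given here, only one measured step touches the same position: a 1.8-fold lower number from compound 1 to compound 2 (0.25 log units; within the scatter), which swaps the chloro for hydrogen and stays within the scatter. Compound 3 also carries a 4-methoxyphenyl, but it differs from compound 4 elsewhere as well, so its value is only a loose hint.

With one small step at this position, no change beyond the scatter is expected, and compound 4 is estimated at 7000 nM, ranging from 3000 nM to 16000 nM, that is a 1.0-fold higher number from compound 1 to compound 4 (0.01 log units; within the scatter).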

Compound 4, concentration for 50% growth inhibition: 4140 nM
Estimate against measurement, compound 4: 1.7-fold (0.23 log units) above, and the stated range covers the measured number.
By their numbers in this assay, from the lowest: compounds 2, 4, 1 and 3 (each within the scatter of the next, the first and the last beyond it).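

In this assay, chloro, hydrogen and methoxy on this aromatic carbon cannot be told apart: methoxy in place of chloro gives a 1.6-fold lower number from compound 1 to compound 4 (0.21 log units; within the scatter), and methoxy in place of hydrogen gives a 1.1-fold higher number from compound 2 to compound 4 (0.03 log units; within the scatter). Going by these compounds alone, the one step beyond the scatter lies elsewhere in the molecule: with the 4-methoxyphenyl kept, 4-hydroxy-3-methoxyphenyl in place of 3,4,5-trimethoxyphenyl gives a 2.9-fold lower number from compound 3 to compound 4 (0.45 log units; beyond the scatter), so the higher number of compound 3 goes with that group and not with its 4-methoxyphenyl. Nothing available explains either result.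

From the compounds shown here alone, whether an amine or a carboxylic acid on this aromatic carbon would shift the number beyond the scatter remains open. Going by these compounds, it is also open how the modest step would read with a 3,4-dimethoxyphenyl, which would separate the hydroxy group from the extra methoxy group.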